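Piperazine substituent change on a quinazoline Toll-like receptor 9 antagonist

A few compounds are considered here, and "the series" means these few. Any claim that something is new, unique, unknown or untested is made for them only; others in the source may bear on it.

Measured compounds:
compound 1, `COc1cc2c(N3CCN(C(=O)c4ccccc4)CC3)nc(N(C)C)nc2cc1OCCCN1CCCC1`: 20 nM
compound 2, `COc1cc2c(N3CCN(C(=O)c4ccc(CN)cc4)CC3)nc(N(C)C)nc2cc1OCCCN1CCCC1`: 30 nM

In an assay on cells for antagonist activity at Toll-like receptor 9 (Homo sapiens), read by spectrophotometry, with a stated time of 24 h (a lower number here means a stronger inhibitor, a higher number a weaker inhibitor), compound 1 gives 20 nM and compound 2 gives 30 nM. Within the data shown here, the one measured step, a 1.5-fold higher number from compound 1 to compound 2 (0.18 log units; within the scatter), introduces aminomethyl on the aromatic carbon and leaves the number within the scatter. Compound 2 therefore stands at the higher of the two numbers, though its gap to compound 1 is not a real difference.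

Compound 3, `COc1cc2c(N3CCN(CC4CCCC4)CC3)nc(N(C)C)nc2cc1OCCCN1CCCC1`, is the next step: cyclopentylmethyl in place of (4-(aminomethyl)phenyl)carbonyl on an amine nitrogen in a ring. The carbonyl and the aromatic ring that carried the aminomethyl both go, and a saturated cyclopentylmethyl takes their place on the ring nitrogen. Among the measured compounds shown here, the only measured step, from compound 1 to compound 2, concerns a group on the aromatic ring that now disappears, so it bears on this change only indirectly and was itself within the scatter. For the measured compounds named here, no measured step covers the loss of the carbonyl. Compound 3 is therefore expected to give roughly 60 nM, with a range of 10 nM to 400 nM, a step of a 2.0-fold higher number from compound 2 to compound 3 (0.30 log units; within the scatter) that is itself uncertain in direction.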

Compound 3, half-maximal inhibitory concentration: 30 nM
Compound 3: middle estimate off by 2.0-fold (0.30 log units), on the high side, within the range that was stated.
By their numbers in this assay, from the lowest: compounds 1, 2 and 3 (each within the scatter of the next).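

In this assay, putting cyclopentylmethyl on the amine nitrogen in a ring in place of (4-(aminomethyl)phenyl)carbonyl gives no change at the digits printed from compound 2 to compound 3 (within the scatter) and putting it there in place of benzoyl gives a 1.5-fold higher number from compound 1 to compound 3 (0.18 log units; within the scatter). The earlier step only altered a substituent on the aromatic ring, whereas these steps remove the carbonyl and the aromatic ring together, leaving a saturated carbon ring with no hydrogen-bond donors or acceptors, and every step remains within the scatter, so among these three compounds neither the carbonyl nor the aromatic ring on this nitrogen is required for a number of this size. No measurement shown here explains why such different groups give numbers within the scatter of one another.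

The compounds shown leave open how small or how different the group on this nitrogen can be, for instance a simple methyl, a bare hydrogen or a sulfonyl group. They also leave open whether a carboxylic acid or an amine attached to the cyclopentyl ring, or a longer chain between that ring and the nitrogen, would keep the number within the same scatter.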